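Swapping Ethyl for 3-Methoxyphenyl on an Aromatic Ether Oxygen

The source may report more compounds than this note shows. Statements on the series, on what has been measured and on what is new or still open speak of the compounds shown alone.

- compound 1 `COc1ccc(Oc2ccccc2NC(C)=C2C(=O)CC(c3ccccc3)CC2=O)cc1`: 160 nM
- compound 2 `CCOc1ccccc1NC(C)=C1C(=O)CC(c2ccccc2)CC1=O`: 180 nM

In a functional assay on HeLa cells (Homo sapiens) for antiproliferative activity, read by cell counting, with a stated time of 3 days (a lower number here means a stronger inhibitor, a higher number a weaker inhibitor), compound 2 gives 180 nM and compound 1 gives 160 nM. With only these two numbers available, compound 2 cannot be told apart from compound 1, since the values lie within the scatter of each other.

The next compound to be tested is compound 3 `COc1cccc(Oc2ccccc2NC(C)=C2C(=O)CC(c3ccccc3)CC2=O)c1`. It differs from compound 2 in one place: 3-methoxyphenyl in place of ethyl on an oxygen on an aromatic ring. In words, this is 3-methoxyphenyl in place of ethyl on an oxygen on an aromatic ring.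

Within the data shown here, one measured step bears on this change. It joins ethyl and 4-methoxyphenyl on that same oxygen, and the name of that group differs from the incoming one only by its number. That step is a 1.1-fold higher number from compound 1 to compound 2 (0.05 log units; within the scatter). Among the measured compounds shown here, no measured compound carries 3-methoxyphenyl itself, so the range has to stay wide.

In this assay, no change beyond the scatter is therefore expected, and the expected step is a 1.1-fold lower number from compound 2 to compound 3 (0.02 log units; within the scatter). Compound 3 is estimated at 170 nM, with an expected range from 70 nM to 420 nM.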

Compound 3, half-maximal inhibitory concentration: 93 nM
Estimate against measurement, compound 3: 1.8-fold (0.26 log units) above; the range from low to high includes it.
By their numbers in this assay, from the lowest: compounds 3, 1 and 2 (each within the scatter of the next).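

In this assay, the group on the oxygen on the aromatic ring has now been varied among three options, and the result is a 1.9-fold lower number from compound 2 to compound 3 (0.29 log units; within the scatter). This shows that ethyl and 3-methoxyphenyl cannot be told apart at this position, even though the entering group has 8 heavy atoms in place of 2 and adds an aromatic ring. Exchanging one methoxyphenyl group for the other gives a 1.7-fold lower number from compound 1 to compound 3 (0.24 log units; within the scatter), so 3-methoxyphenyl and 4-methoxyphenyl cannot be told apart either, and no information is at hand to explain any of these numbers.

On these data alone, the three compounds carry only ethyl or a methoxyphenyl group on this oxygen, and all three values lie within the scatter of one another, so it remains open how far this insensitivity extends. A longer chain such as butyl in place of ethyl, a plain phenyl group, 2-methoxyphenyl, or a phenyl group carrying an amine or a carboxylic acid could each show whether a change at this position can move the number beyond the scatter.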